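The compounds below may be only part of what the source reports. "The series", "measured", "known", "first", "only" and "open" are said of these compounds alone.

Compound 1 `Nc1nn(C(=O)Nc2ccc(Cc3ccccc3)cc2)c2ccccc12` gives 7870 nM in a functional assay on NCI/ADR-RES cells (Homo sapiens) for inhibition, read by sulforhodamine B assay, with a stated time of 48 h; on this read-out higher numbers stand for weaker inhibition of growth and lower numbers for stronger inhibition of growth. Within the data shown here, of the two compounds measured so far, compound 1 gives the lower number. The other one, compound 2 `COc1ccccc1NC(=O)n1nc(N)c2ccccc21`, gives 90700 nM in this assay, a gap that lies beyond the usual scatter; as compound 2 differs from compound 1 in more than one place, only the two numbers themselves can be compared.

Compound 3 `CCCCOc1ccc(NC(=O)n2nc(N)c3ccccc32)cc1` has not been measured. It differs from compound 1 by a single change, (butoxy in place of benzyl on an aromatic carbon). Among the measured compounds shown here, no pair of measured compounds shows this exact change, so its effect can only be guessed. The expectation is a modest step toward weaker inhibition of growth, a 1.9-fold higher number from compound 1 to compound 3 (0.28 log units; within the scatter), with the possibility that the step stays within the scatter. Compound 3 is therefore estimated to give 15000 nM in this assay, within a range from 4000 nM to 60000 nM.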

Compound 3, concentration for 50% growth inhibition: 23700 nM
Beside the measured number, compound 3's estimate is 1.6-fold (0.20 log units) below it; measured number inside the range.
By their numbers in this assay, from the lowest: compound 1; then compound 3; then compound 2.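

Among these compounds, replacing benzyl with butoxy on this aromatic carbon, para to a large group, gives the first direct reading of a change at this position: in this assay the swap gives a 3.0-fold higher number from compound 1 to compound 3 (0.48 log units; beyond the scatter) for the change in growth inhibition. The ring of carbon only can therefore be lost at this place, and an open chain with one hydrogen-bond acceptor put there, at the price of a modest but real weakening. No measurement on hand explains this step.

Among the compounds shown here, the single swap changes the ring and the oxygen together, so their separate contributions stay open. A pentyl chain, with no oxygen and no ring, or a phenoxy group, with both, would help to pull the two apart.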